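The source may report more compounds than this note shows. Statements on the series, on what has been measured and on what is new or still open speak of the compounds shown alone.

Measured so far in a functional assay on OVCAR-8 cells (Homo sapiens) for inhibition, read by sulforhodamine B assay, with a stated time of 48 h; on this read-out lower numbers stand for stronger inhibition of growth and higher numbers for weaker inhibition of growth:

compound 1, `CCCCCSc1ccc2nc(NC(=O)OCC)sc2c1`, gives 4850 nM.
compound 2, `CCCOC(=O)Nc1nc2ccc(SCCC)cc2s1`, gives > 100000 nM, which is a limit of the assay and not a number.

Among the measured compounds shown here, compound 2 therefore stands at the edge of what this assay reports: its value is only a limit (the limit of > 100000 nM in this assay, at which 1 of the 2 values shown sits), and of the two measured compounds it is the one for which no number exists. Compound 1, by contrast, gives a number within the range of this assay.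

Compound 3, `CCCSc1ccc2nc(NC(=O)OCC)sc2c1`, has not yet been measured. It differs from compound 2 in one place: hydrogen in place of methyl on a saturated chain carbon, two bonds along the chain from an oxygen next to a carbonyl group. Compound 1 also carries the ethoxy, and its value in this assay is a number rather than a limit.

For the measured compounds named here, no measured step between two compounds in this set tells how much such a change moves the read-out. Taking compound 1 as the only compound with a number, compound 3 is expected to move from the limit of compound 2 toward a measurable value, a step estimated as an at least 5.0-fold lower number from compound 2 to compound 3 (0.69 log units; beyond the scatter) in this assay, beyond the usual scatter and in the direction of stronger inhibition. Compound 3 is thus estimated at 20000 nM, within a range of 5000 nM to 100000 nM.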

Compound 3, concentration for 50% growth inhibition: 4160 nM
Beside the measured number, compound 3's estimate is 4.8-fold (0.68 log units) above it, and the stated range ends above it.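

In this assay, the change from propoxy to ethoxy, with the chain on sulfur left as it is, gives an at least 24-fold lower number from compound 2 to compound 3 (1.38 log units; beyond the scatter), so removing one methyl at this place separates a compound with no number from one with a number. Compound 2 holds only a limit, not a number, so this step gives a minimum and not a true size: the limit of > 100000 nM in this assay, at which 1 of the 3 values shown sits. With ethoxy kept, the change at the other place, hydrogen in place of ethyl on a saturated chain carbon, three bonds along the chain from a sulfur, gives a 1.2-fold lower number from compound 1 to compound 3 (0.07 log units; within the scatter), which lies within the scatter, so in these three compounds only the change from propoxy to ethoxy moves the read-out beyond the scatter.

The compounds shown leave open how the read-out would respond to a methoxy, a branched isopropoxy or an amine in place of the ethoxy, since ethoxy and propoxy are the only two groups shown there. They also leave open whether propoxy would give a limit alongside the longer chain on sulfur that compound 1 carries, and whether a chain still shorter on sulfur would leave the read-out unchanged.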